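Cytotoxicity notes on the series, compound 1 to compound 4

The source may report more compounds than this note shows. Statements on the series, on what has been measured and on what is new or still open speak of the compounds shown alone.

Measured compounds:
compound 1 `COc1ccc([C@H]2CC(=O)N(c3cccc(O)c3)C2)cc1OC1CCCC1` — > 10000 nM
compound 2 `COc1ccc([C@H]2CC(=O)N(c3cccc(C#N)c3)C2)cc1OC1CCCC1` — > 10000 nM
compound 3 `COc1ccc([C@H]2CC(=O)N(c3ccc(C#N)cc3)C2)cc1OC1CCCC1` — > 10000 nM

In a functional assay on HEK293 cells (Homo sapiens) for cytotoxicity (on this read-out higher numbers stand for lower toxicity in this test and lower numbers for higher toxicity in this test), compound 1 gives > 10000 nM, which is a limit of the assay and not a number. In this assay compound 2 likewise gives > 10000 nM, again a limit. In this assay compound 3 gives > 10000 nM, also a limit. Compound 1 therefore stands only at a limit, as do the two other compounds.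

The three steps that can be drawn among them are all unreadable: a step that the two limits leave unreadable from compound 1 to compound 2; a step that the two limits leave unreadable from compound 1 to compound 3; a step that the two limits leave unreadable from compound 2 to compound 3. Among the measured compounds shown here, the single piece of evidence is the limit of > 10000 nM in this assay, at which 3 of the 3 values shown sit.

Compound 4 `COc1ccc([C@H]2CC(=O)N(c3ccccc3C(F)(F)F)C2)cc1OC1CCCC1` differs from compound 1 by 2-(trifluoromethyl)phenyl in place of 3-hydroxyphenyl on an amide-type nitrogen in a ring. For the measured compounds named here, the measured steps show only that exchanging one aryl group for another on the ring nitrogen has not brought any compound below the limit in this assay, so no readable step can be expected in either direction. Because (the limit of > 10000 nM in this assay, at which 3 of the 3 values shown sit), compound 4 is expected to sit at the limit as well. For compound 4 the estimate is 15000 nM, with a range from 8000 nM to 40000 nM. This estimate corresponds to an expected step that the limit leaves unreadable from compound 1 to compound 4.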

Compound 4, half-maximal cytotoxic concentration: > 10000 nM
Compound 4: only a limit was reported; the forecaster's own chance of this, stated with the estimate: 80%; the middle value lies beyond the limit too.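

In this assay compound 4 gives > 10000 nM, a limit of the assay and not a number. No new step can be read from compound 1, compound 2 or compound 3 to compound 4: the limit of > 10000 nM in this assay, at which 4 of the 4 values shown sit.

The compounds shown leave open whether the aryl group on the amide-type nitrogen separates compound 1, compound 2, compound 3 and compound 4 at all in this assay.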